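Swapping nitro for hydrogen on compound 2

The source may hold more compounds than are shown below. What is called first, only, known or untested is meant among the compounds shown, and "the series" means these compounds.

Compound 1 `OC[C@H]1O[C@H](Oc2ccc(-n3ccc4ccccc43)cc2Cl)[C@@H](O)[C@@H](O)[C@@H]1O` (1.8)
Compound 2 `O=[N+]([O-])c1ccc2c(c1)CCN2c1ccc(O[C@H]2O[C@H](CO)[C@@H](O)[C@H](O)[C@@H]2O)c(Cl)c1` (1.9)

Both compounds were measured in a physicochemical assay for lipophilicity, using the shake flask method, in phosphate buffer, measured as octanol-water partition, with a stated time of 2 h, at pH 7.4, tested at 1 uM (on this read-out higher numbers stand for higher lipophilicity and lower numbers for lower lipophilicity), and compound 2 stands within the usual scatter of compound 1, so the two cannot be ranked. The next compound, compound 3 `OC[C@H]1O[C@H](Oc2ccc(N3CCc4ccccc43)cc2Cl)[C@@H](O)[C@@H](O)[C@@H]1O`, is compound 2 with hydrogen in place of nitro on an aromatic carbon. Going by the values given here, no pair of measured compounds shows this swap on its own, so the expectation rests on thin evidence. One hint comes from compound 1 (1.8), which has no nitro, although its core also differs from that of compound 2. The expected change is small, a slight rise that stays within the scatter (a number 0.10 log units higher from compound 2 to compound 3 (within the scatter)). The estimated value for compound 3 is 2 (expected range 1.6 to 2.4).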

Compound 3, distribution coefficient: 2.8
For compound 3 the middle estimate is 0.80 log units below the measured one; the measured number lies above the stated range.
By their numbers in this assay, from the lowest: compounds 1 and 2 (each within the scatter of the next); then compound 3.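

In this assay, hydrogen in place of nitro on this aromatic carbon gives a number 0.90 log units higher from compound 2 to compound 3 (beyond the scatter), so this single swap moves the number well beyond the scatter. Going by these compounds alone, with no nitro on either compound, 2,3-dihydro-1H-indol-1-yl in place of 1H-indol-1-yl also gives a clear step, a number 1.00 log units higher from compound 1 to compound 3 (beyond the scatter), showing that a change in either of these two places can separate compounds on this read-out. Nothing available here explains either step.

Going by these compounds, it remains open whether an amine, a methoxy group or a carboxylic acid on the same aromatic carbon would give a number closer to that of compound 2 or that of compound 3. Also open, on these data alone, is whether the nitro-to-hydrogen swap would give a step of similar size on the core of compound 1.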